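Chain Lengthening in a Glycoside Series Against HL-60 Cells

This account rests on a few compounds, and the source may have more. Where it says the series, first, only, none or still open, it means among the compounds named here.

Of the compounds shown here, two from this series have been tested in a functional assay on HL-60 cells (Homo sapiens) for inhibition; a higher number here means a weaker inhibitor, a lower number a stronger inhibitor. Compound 1 `CC1OC(OC2CCCCC2OCCCCC(C(=O)O)C(=O)O)C(O)C(O)C1O` reaches only the limit of the assay, giving > 5000000 nM. Compound 2 `CC1OC(OC2CCCCC2OCCCCCCC(C(=O)O)C(=O)O)C(O)C(O)C1O` likewise returns only a limit, > 5000000 nM. Among the measured compounds shown here, the one measured step, a step that the two limits leave unreadable from compound 1 to compound 2, is therefore unreadable in size, and the sole evidence on the series is the limit of > 5000000 nM in this assay, at which 2 of the 2 values shown sit. Compound 2 thus stands at the limit, with no numerical potency known for it. Compound 3 `CC1OC(OC2CCCCC2OCCCCCCCCCCC(C(=O)O)C(=O)O)C(O)C(O)C1O` carries the change (5,5-dicarboxypentyl in place of dicarboxymethyl on a saturated chain carbon, six bonds along the chain from an oxygen on a saturated carbon), a further lengthening of the same kind of chain that already separated compound 2 from compound 1. With both earlier values sitting at the limit, no readable step bears on this change, and compound 3 is expected to behave the same way, with a number no higher from compound 2 to compound 3 (the limit leaves the size open) expected to stay within the scatter. In this assay compound 3 is estimated at 5000000 nM, with a range from 1000000 nM to 20000000 nM, most probably reported again only as a limit.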

Compound 3, half-maximal inhibitory concentration: > 5000000 nM
Compound 3 was reported as a limit; the forecaster's own chance of this, stated with the estimate: 85%; the middle value lies on the limit itself.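

Compound 3, like compound 2, was returned only as a limit, so the step between them cannot be read in this assay. The compounds shown leave open what numerical potency any of them has, and whether chain length affects it at all.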